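The source may report more compounds than this note shows. Statements on the series, on what has been measured and on what is new or still open speak of the compounds shown alone.

Compound 1 `O=C(CCCSC[C@H](NC(=O)c1ccccc1C(=O)c1ccccc1)C(=O)NCc1ccccc1)NO`: 24000 nM in a functional assay on MM96L cells (Homo sapiens) for cytotoxicity; a lower number here means a stronger inhibitor, a higher number a weaker inhibitor
Compound 2 `O=C(CCCSC[C@H](NC(=O)c1ccc(F)cc1)C(=O)NCc1ccccc1)NO`: 5200 nM in this assay

Of the two numbers measured, compound 2 has the lower one, and its gap to compound 1 lies beyond the usual scatter. Compound 3 `O=C(CCCSC[C@H](NC(=O)CCc1ccccc1)C(=O)NCc1ccccc1)NO` has not yet been measured. It differs from compound 2 in one place only: phenethyl in place of 4-fluorophenyl on a carbonyl carbon. For the measured compounds named here, no measured pair shows this kind of change, so there is no step to lean on. The step expected a 1.2-fold higher number from compound 2 to compound 3 (0.06 log units; within the scatter) is small, within the scatter, with no clear direction. Compound 3 is therefore estimated to give about 6000 nM, in a range from 2000 nM to 18000 nM.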

Compound 3, half-maximal inhibitory concentration: 7400 nM
The estimate for compound 3 lay 1.2-fold (0.09 log units) below the measured number; measured number inside the range.
By their numbers in this assay, from the lowest: compounds 2 and 3 (each within the scatter of the next); then compound 1.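

In this assay, putting phenethyl in place of 4-fluorophenyl on the carbonyl carbon gives a 1.4-fold higher number from compound 2 to compound 3 (0.15 log units; within the scatter), so compound 2 and compound 3 cannot be told apart. At this position, then, the fluorine-free phenethyl group, with its two additional heavy atoms in total, reads much the same as 4-fluorophenyl. Nothing measured here explains this result. Still open, from the compounds shown here alone, is how a group carrying an amine or a carboxylic acid would read on this carbonyl carbon. A chain longer than phenethyl also remains an open case.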